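This account rests on a few compounds, and the source may have more. Where it says the series, first, only, none or still open, it means among the compounds named here.

In an ADME assay on the whole organism (Mus musculus, strain CD-1) for pharmacokinetics, at a dose of 10 mg/kg by the oral route (a higher number here means more compound in the circulation at the dose given, a lower number less compound in the circulation), compound 1 `CCOc1cc([C@](O)(CCN(C)C)[C@@H](c2cc3cc(Br)ccc3nc2OC)c2cccc(OC)c2F)cc(OC)n1` gives 4000 ng.h/mL, compound 2 `CCOc1cc([C@](O)(CCN(C)C)[C@@H](c2cc3cc(Br)ccc3nc2OC)c2ccnc(OC)c2OC)cc(OC)n1` gives 12700 ng.h/mL and compound 3 `COc1cc([C@](O)(CCN(C)C)[C@@H](c2cc3cc(Br)ccc3nc2OC)c2cccc(OC)c2F)cc(OC(C)C)n1` gives 9000 ng.h/mL. Compound 3 thus lies within the scatter of compound 2, and both stand beyond the scatter above compound 1. Compound 4 `COc1cc([C@](O)(CCN(C)C)[C@@H](c2cc3cc(Br)ccc3nc2OC)c2ccnc(OC)c2OC)cc(OC(C)C)n1` differs from compound 3 by 2,3-dimethoxypyridin-4-yl in place of 2-fluoro-3-methoxyphenyl on a saturated chain carbon bound to an aromatic carbon and a saturated chain carbon: 2,3-dimethoxypyridin-4-yl in place of 2-fluoro-3-methoxyphenyl. Going by the values given here, the same exchange gave a 3.2-fold higher number from compound 1 to compound 2 (0.50 log units; beyond the scatter), the only direct precedent. From the compounds shown here alone, the methyl change gave a 2.3-fold higher number from compound 1 to compound 3 (0.35 log units; beyond the scatter), and compound 4 carries both changes, whose combination is untested. An upward move in this assay, beyond the scatter and slightly smaller than the precedent, is expected: a 2.8-fold higher number from compound 3 to compound 4 (0.44 log units; beyond the scatter). For compound 4 the estimate is 25000 ng.h/mL, within an expected range of 12000 ng.h/mL to 50000 ng.h/mL.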

Compound 4, area under the concentration-time curve: 5600 ng.h/mL
Compound 4: middle estimate off by 4.5-fold (0.65 log units), on the high side, outside the stated range (below it).
By their numbers in this assay, from the lowest: compounds 1, 4, 3 and 2 (each within the scatter of the next, the first and the last beyond it).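

In this assay, the effect of 2,3-dimethoxypyridin-4-yl in place of 2-fluoro-3-methoxyphenyl depends on the core, with a 1.6-fold lower number from compound 3 to compound 4 (0.21 log units; within the scatter) and no gain retained: the same change on two cores in this assay, a 3.2-fold higher number (0.50 log units; beyond the scatter) from compound 1 to compound 2 and a 1.6-fold lower number (0.21 log units; within the scatter) from compound 3 to compound 4, 5.1-fold (0.71 log units) apart, beyond the scatter of two such steps

The added methyl also changes direction on the other core, with a 2.3-fold lower number from compound 2 to compound 4 (0.36 log units; beyond the scatter): the same change on two cores in this assay, a 2.3-fold higher number (0.35 log units; beyond the scatter) from compound 1 to compound 3 and a 2.3-fold lower number (0.36 log units; beyond the scatter) from compound 2 to compound 4, 5.1-fold (0.71 log units) apart, beyond the scatter of two such steps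

Across these compounds the two changes do not add, and each raises the number only when made on compound 1.

Still open, from the compounds shown here alone, is whether a longer chain in place of the added methyl, or an amine on the ring at the exchanged place, would behave the same way. The area under the curve alone does not separate absorption from clearance.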